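A few compounds are considered here, and "the series" means these few. Any claim that something is new, unique, unknown or untested is made for them only; others in the source may bear on it.

Compound 1 `O=C(Nc1nnc(-c2ccc(Cl)cc2)s1)c1ccccc1I`, compound 2 `O=C(Nc1nnc(-c2ccc(Cl)cc2)s1)c1ccccc1C(F)(F)F` and compound 3 `COc1cccc(OC)c1C(=O)Nc1nnc(-c2ccc(C(C)C)cc2)s1` share one core, an amide that joins a substituted benzoyl group to a ring carrying a second substituted phenyl group. In a functional assay on the whole organism (integument) for inhibition, with Chilo suppressalis as the target, read by scintillation counting, with a stated time of 72 h (a higher number here means a weaker inhibitor, a lower number a stronger inhibitor), compound 1 gives only a limit, > 5010 nM. Compound 2 likewise gives only a limit in this assay, > 16500 nM. The step that the two limits leave unreadable from compound 1 to compound 2 stays hidden because the limit of > 5010 nM in this assay, at which 1 of the 3 values shown sits, and the limit of > 16500 nM in this assay, at which 1 of the 3 values shown sits, are all that these two compounds show. Compound 3 is the only one of the three with a real number: in this assay compound 3 gives 398 nM, so it stands alone as the one measured anchor.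

Compound 4 `CCOc1ccc(-c2nnc(NC(=O)c3c(OC)cccc3OC)s2)cc1` differs from compound 3 by ethoxy in place of isopropyl on an aromatic carbon. For the measured compounds named here, no measured step bears on this change; the single step that was measured concerns the other end of the core and could not be read anyway. With nothing to point either way, the expectation is that the change from isopropyl to ethoxy moves the number by no more than the usual scatter, so the estimated step of a 1.3-fold higher number from compound 3 to compound 4 (0.10 log units; within the scatter) is small and of uncertain direction. Compound 4 is therefore expected to give about 500 nM in this assay, within a range from 160 nM to 1600 nM.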

Compound 4, half-maximal inhibitory concentration: 646 nM
Compound 4: middle estimate off by 1.3-fold (0.11 log units), on the low side; the range from low to high includes it.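

For the compounds shown here, compound 4 supplies the first step that can be read in this assay, as the one earlier step rests on two limits and cannot be read. At this position, on an aromatic carbon para to a large group, ethoxy in place of isopropyl gives a 1.6-fold higher number from compound 3 to compound 4 (0.21 log units; within the scatter), so the swap of one three-atom group for another, with an oxygen and a hydrogen-bond acceptor entering, leaves a step within the usual scatter, and the two compounds cannot be told apart in this assay. Nothing measured here explains this step, and the only other data on hand are the two limits of compounds that carry different groups elsewhere on the shared core.

On these data alone, one pair cannot show how far this position tolerates change, so it remains open whether an amine, a carboxylic acid or a longer chain such as butoxy in the same place would also give a step within the scatter. Compound 1 and compound 2 differ from compound 3 in more than one place, which leaves open whether the same swap would behave alike on a different benzoyl group.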